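Compound 3 to compound 4: a piperazine replaces the amine

The source may report more compounds than this note shows. Statements on the series, on what has been measured and on what is new or still open speak of the compounds shown alone.

In an ADME assay on microsomes from liver (Homo sapiens) for metabolic stability, read by LC-MS, tested at 1 uM (on this read-out lower numbers stand for slow clearance and higher numbers for fast clearance), compound 3 `CC(C)(O)CNCCCOc1ccc([C@H]2CC[C@]3(CC2)OOC2(O3)C3CC4CC(C3)CC2C4)cc1` gives 8 mL.min-1.g-1. Compound 2 `c1cc([C@H]2CC[C@]3(CC2)OOC2(O3)C3CC4CC(C3)CC2C4)ccc1OCCCNC1CCOCC1` gives 10 mL.min-1.g-1, and the step between them is a 1.3-fold lower number from compound 2 to compound 3 (0.10 log units; within the scatter). Compound 1 `NCCCCCOc1ccc([C@H]2CC[C@]3(CC2)OOC2(O3)C3CC4CC(C3)CC2C4)cc1` has no number, only a limit of the assay, < 7 mL.min-1.g-1.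

Compound 4 `CS(=O)(=O)N1CCN(CCCOc2ccc([C@H]3CC[C@]4(CC3)OOC3(O4)C4CC5CC(C4)CC3C5)cc2)CC1` keeps the shared core but carries 4-(methylsulfonyl)piperazin-1-yl in place of (2-hydroxy-2-methylpropyl)amino on a saturated chain carbon, three bonds along the chain from an oxygen on an aromatic ring. Among the compounds with values here, no measured compound carries this group. The nearest evidence is the steps at the same place, which are an at least 1.4-fold higher number from compound 1 to compound 2 (0.15 log units; that floor lies within the scatter) and an at least 1.1-fold higher number from compound 1 to compound 3 (0.05 log units; that floor lies within the scatter), both of them floors only, together with the step already given between the two measured amines. None of these goes beyond the scatter, so no step beyond the scatter is expected here either. The expected step is a 1.5-fold higher number from compound 3 to compound 4 (0.18 log units; within the scatter), a small rise at most. For compound 4 the estimated value is 12 mL.min-1.g-1, with an expected range of 7 mL.min-1.g-1 to 30 mL.min-1.g-1.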

Compound 4, intrinsic clearance in microsomes: 68 mL.min-1.g-1
Compound 4: the middle estimate sits 5.7-fold (0.75 log units) below what was measured, outside the stated range (above it).
By their numbers in this assay, from the lowest: compounds 3 and 2 (each within the scatter of the next); then compound 4. At a limit, below all of these: compound 1.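

In this assay, within the data shown here, this position turns out to be able to move the number beyond the scatter, which no earlier step did: 4-(methylsulfonyl)piperazin-1-yl in place of (2-hydroxy-2-methylpropyl)amino gives an 8.5-fold higher number from compound 3 to compound 4 (0.93 log units; beyond the scatter), and in place of (oxan-4-yl)amino it gives a 6.8-fold higher number from compound 2 to compound 4 (0.83 log units; beyond the scatter). Against the 2-aminoethyl group the change also lies beyond the scatter, with an at least 9.7-fold higher number from compound 1 to compound 4 (0.98 log units; beyond the scatter), though that step is only a floor. Compound 1 gives a limit and not a number: the limit of < 7 mL.min-1.g-1 in this assay, at which 1 of the 4 values shown sits.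

The compounds shown leave open whether the rise goes with the piperazine ring or with the methylsulfonyl group on it; a plain piperazin-1-yl or a 4-acetylpiperazin-1-yl on the same chain carbon could separate the two. Nothing shown tells why the number rises.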